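A few compounds are considered here, and "the series" means these few. Any claim that something is new, unique, unknown or untested is made for them only; others in the source may bear on it.

Values in a functional assay on NCI-H460 cells (Homo sapiens) for cytotoxicity, read by MTT assay, with a stated time of 72 h; on this read-out lower numbers stand for stronger inhibition and higher numbers for weaker inhibition:
- compound 1 `CCCCNC1=CC(=O)C=C(C(C)(C)C)C1=O` 14000 nM
- compound 2 `CCCCCCCCNC1=CC(=O)C=C(C(C)(C)C)C1=O` 20000 nM
- compound 3 `CCNC1=CC(=O)C(C(C)(C)C)=CC1=O` 64000 nM

Not yet measured: compound 4 `CNC1=CC(=O)C(C(C)(C)C)=CC1=O`.

Compound 3 stands at 64000 nM, the highest number of the three, and its gaps to compound 1 and compound 2 lie beyond the scatter. The change to compound 4 is hydrogen in place of methyl on a saturated chain carbon bound to an amine nitrogen, or ethylamino to methylamino.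

Going by the values given here, only one measured step bears on this change: a 1.4-fold higher number from compound 1 to compound 2 (0.15 log units; within the scatter), with butyl in place of hydrogen on a saturated chain carbon, four bonds along the chain from an amine nitrogen. That step stays within the scatter, although more atoms change there than here. The evidence is indirect, since it comes from the core of compound 1, which is not the core of compound 3. Among the compounds with values here, no measured pair tests a chain change on the core of compound 3.

No step beyond the scatter is therefore expected in this assay, and the data favour no direction. The estimated step is a 1.1-fold lower number from compound 3 to compound 4 (0.03 log units; within the scatter). Compound 4 is expected at 60000 nM, with an estimated range from 30000 nM to 110000 nM.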

Compound 4, half-maximal inhibitory concentration: 63000 nM
For compound 4 the middle estimate is 1.1-fold (0.02 log units) below the measured one; low and high end bracket the measured number.
By their numbers in this assay, from the lowest: compounds 1 and 2 (each within the scatter of the next); then compounds 4 and 3 (each within the scatter of the next).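

In this assay, going by these compounds alone, hydrogen in place of methyl on a saturated chain carbon bound to an amine nitrogen gives a 1.0-fold lower number from compound 3 to compound 4 (0.01 log units; within the scatter) and stays within the scatter, which is the first direct reading of a chain change on the core of compound 3. Within the data shown here, until now the only chain step available was a 1.4-fold higher number from compound 1 to compound 2 (0.15 log units; within the scatter) on the core of compound 1, so a step within the scatter now stands on each of the two cores, though for different chain changes. Ethylamino and methylamino are not separated by this read-out on the core of compound 3, and no supporting measurement bears on this result.

Still open, from the compounds shown here alone, is whether a longer chain on the core of compound 3, such as butylamino or octylamino, would read any differently from ethylamino and methylamino, which would also give a pair for setting the two cores side by side at one chain. Also open is whether a chain ending in a carboxylic acid or a primary amine would move the number on either core, since all the chains shown are plain alkyl groups.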